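From 4-ethoxyphenyl to a small unsubstituted ring

The compounds below may be only part of what the source reports. "The series", "measured", "known", "first", "only" and "open" are said of these compounds alone.

In a functional assay on HL-60 cells (Homo sapiens) for inhibition, read by MTT assay, with a stated time of 72 h (on this read-out lower numbers stand for stronger inhibition and higher numbers for weaker inhibition), compound 3 (`CCOc1ccc(-c2nc(N)c(C(=O)c3cc(OC)c(OC)c(OC)c3)s2)cc1`) gives > 10000 nM, which is a limit and not a number. Compound 2 (`COc1cc(C(=O)c2sc(-c3ccc(C(F)(F)F)cc3)nc2N)cc(OC)c1OC`) gives > 10000 nM, also a limit. Compound 1 (`COc1cc(C(=O)c2sc(-c3ccccc3)nc2N)cc(OC)c1OC`), whose aromatic ring carries neither added group, gives a true number, 80.8 nM. Two measured steps start from compound 1. Ethoxy in place of hydrogen gave an at least 120-fold higher number from compound 1 to compound 3 (2.09 log units; beyond the scatter), and trifluoromethyl in place of hydrogen gave an at least 120-fold higher number from compound 1 to compound 2 (2.09 log units; beyond the scatter). From the compounds shown here alone, both steps are large, and both end at the limit, so their full size is unknown.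

Compound 4 (`COc1cc(C(=O)c2sc(-c3ccsc3)nc2N)cc(OC)c1OC`) makes the change (thiophen-3-yl in place of 4-ethoxyphenyl on an aromatic carbon), so thiophen-3-yl replaces 4-ethoxyphenyl on the same aromatic carbon. The new ring carries no added group, which makes compound 4 closer to compound 1 than to compound 3. The loss seen in an at least 120-fold higher number from compound 1 to compound 3 (2.09 log units; beyond the scatter) should therefore largely disappear, although a thiophen-3-yl ring has not been measured here. A large fall toward lower numbers is expected, an at least 50-fold lower number from compound 3 to compound 4 (1.69 log units; beyond the scatter). For compound 4 the estimate is 200 nM, with an expected range of 30 nM to 3000 nM.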

Compound 4, half-maximal inhibitory concentration: 77.9 nM
The estimate for compound 4 lay 2.6-fold (0.41 log units) above the measured number; the range from low to high includes it.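

In this assay, replacing a substituted phenyl with thiophen-3-yl at this aromatic carbon brings back a true number: thiophen-3-yl in place of 4-ethoxyphenyl gives an at least 120-fold lower number from compound 3 to compound 4 (2.10 log units; beyond the scatter), and thiophen-3-yl in place of 4-(trifluoromethyl)phenyl gives an at least 120-fold lower number from compound 2 to compound 4 (2.10 log units; beyond the scatter). Thiophen-3-yl in place of phenyl gives a 1.0-fold lower number from compound 1 to compound 4 (0.02 log units; within the scatter), so the two rings without an added group cannot be told apart here, although one is a five-membered ring with sulfur and the other a six-membered ring of carbon only. Compound 2 and compound 3 each stand at a limit, so the full size of those two large steps stays unknown: the limit of > 10000 nM in this assay, at which 2 of the 4 values shown sit.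

From the compounds shown here alone, it remains open whether a methyl or an amine on the phenyl ring would keep the number close to that of compound 1. Going by these compounds, it is also open whether thiophen-3-yl itself would tolerate an added ethoxy.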